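Swapping a difluorophenyl for a methoxyphenyl on the pyrrolidine

The source may report more compounds than this note shows. Statements on the series, on what has been measured and on what is new or still open speak of the compounds shown alone.

Three compounds share a core built around a pyridazinone linked to a basic five-membered ring that carries an aromatic group. Compound 1 `COc1ccc(-n2nc(Sc3ccc(Cl)cc3)cc(CC[C@@H](C)NC(=O)[C@H]3CCNC[C@@H]3c3ccc(Cl)cc3Cl)c2=O)cc1` gives 36 nM in an assay on CHO cells for binding affinity to Melanocortin receptor 4 (Homo sapiens); on this read-out higher numbers stand for weaker inhibition and lower numbers for stronger inhibition. Compound 2 `COc1ccc(-n2nc(Sc3ccc(Cl)cc3)cc(CC[C@@H](C)NC(=O)[C@H]3CNC[C@@H]3c3ccccc3F)c2=O)cc1` gives 160 nM, and compound 3 `COc1ccc(-n2nc(Sc3ccc(Cl)cc3)cc(CC[C@@H](C)NC(=O)[C@H]3CNC[C@@H]3c3ccc(F)cc3F)c2=O)cc1` gives 60 nM. Among the compounds with values here, compound 3 thus sits in the middle: its gap to compound 1 is within the scatter, while the step of a 2.7-fold lower number from compound 2 to compound 3 (0.43 log units; beyond the scatter) is beyond it and is the only measured step in this set.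

Compound 4 `COc1ccc([C@H]2CNC[C@@H]2C(=O)N[C@H](C)CCc2cc(Sc3ccc(Cl)cc3)nn(-c3ccc(OC)cc3)c2=O)cc1` differs from compound 3 by 4-methoxyphenyl in place of 2,4-difluorophenyl on a saturated ring carbon. Within the data shown here, no measured step involves a methoxy group on this ring, so the expectation rests only on the fluorine step. That step showed that adding a fluoro to this aromatic ring lowered the number; removing both fluorines and placing a methoxy instead is a larger change without a direct precedent. A modest rise in the number is therefore expected, on the order of a 2.5-fold higher number from compound 3 to compound 4 (0.40 log units; beyond the scatter), so compound 4 is estimated at 150 nM, with a range from 50 nM to 500 nM in this assay.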

Compound 4, half-maximal inhibitory concentration: 19 nM
Compound 4: middle estimate off by 7.9-fold (0.90 log units), on the high side, and the stated range ends above it.
By their numbers in this assay, from the lowest: compounds 4, 1 and 3 (each within the scatter of the next, the first and the last beyond it); then compound 2.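

In this assay the aromatic group on this saturated ring carbon needs no fluorine to reach a low number: 4-methoxyphenyl in place of 2,4-difluorophenyl gives a 3.2-fold lower number from compound 3 to compound 4 (0.50 log units; beyond the scatter) even though the entering group carries no fluorine at all. The same group gives an 8.4-fold lower number from compound 2 to compound 4 (0.93 log units; beyond the scatter) when it replaces 2-fluorophenyl, so the earlier fluoro step did not mean that fluorine itself is what this position favours. No measurement at hand explains why the methoxy group has this effect.

Still open, as far as these compounds go, is whether the oxygen of the methoxy group matters, which a hydroxy or an ethoxy group in its place, or a plain phenyl, would help to test. Also open, from the compounds shown here alone, is whether the same swap would hold on the core of compound 1.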